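Fluoro in place of nitro: expectation for compound 3

This account rests on a few compounds, and the source may have more. Where it says the series, first, only, none or still open, it means among the compounds named here.

- compound 1 `Cc1cc(Nc2nc(Nc3ccc(C(=O)NC4CC(C)(C)N([O])C(C)(C)C4)cc3)ncc2[N+](=O)[O-])no1`: 26800 nM
- compound 2 `Cc1cc(Nc2nc(Nc3ccc(C(=O)NC4CC(C)(C)N([O])C(C)(C)C4)cc3)ncc2[N+](=O)[O-])n[nH]1`: > 100000 nM

In a functional assay on LoVo cells (Homo sapiens) for antiproliferative activity, read by MTT assay, with a stated time of 48 h (on this read-out lower numbers stand for stronger inhibition and higher numbers for weaker inhibition), compound 2 gives > 100000 nM, which is a limit and not a number. Compound 3 `Cc1cc(Nc2nc(Nc3ccc(C(=O)NC4CC(C)(C)N([O])C(C)(C)C4)cc3)ncc2F)n[nH]1` keeps the 5-methyl-1H-pyrazol-3-yl group of compound 2 and differs by fluoro in place of nitro on an aromatic carbon. For the measured compounds named here, the only measured step, an at least 3.7-fold higher number from compound 1 to compound 2 (0.57 log units; beyond the scatter), lies at another place and does not cover this change, so it offers weak guidance. A modest move to a lower number is expected, with the estimated step being an at least 1.6-fold lower number from compound 2 to compound 3 (0.22 log units; that floor lies within the scatter). Compound 3 is estimated at 60000 nM, with an expected range of 15000 nM to 200000 nM.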

Compound 3, half-maximal inhibitory concentration: 42200 nM
Compound 3: middle estimate off by 1.4-fold (0.15 log units), on the high side; low and high end bracket the measured number.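

In this assay, the change on the aromatic carbon ortho to the (5-methyl-1H-pyrazol-3-yl)amino group gives an at least 2.3-fold lower number from compound 2 to compound 3 (0.37 log units; beyond the scatter). With this group in place, the nitro group is therefore not needed for a measurable number, and activity responds to the substituent at this position as well as to the group changed between compound 1 and compound 2. The size of the step remains a floor because compound 2 carries a limit and not a number: the limit of > 100000 nM in this assay, at which 1 of the 3 values shown sits.

Still open, on these data alone, is how an amine or chloro would read at this position. Also open, as far as these compounds go, is whether fluoro in place of nitro moves the number in the same direction with the 5-methyl-1,2-oxazol-3-yl group of compound 1.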